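This account rests on a few compounds, and the source may have more. Where it says the series, first, only, none or still open, it means among the compounds named here.

In an ADME assay on Vero cells (Chlorocebus sabaeus) for cytotoxicity, read by MTT assay, with a stated time of 48 h (on this read-out higher numbers stand for weaker inhibition and lower numbers for stronger inhibition), the measured compounds stand as follows.
compound 1 `O=C(OC1CCC(CN2CCN(c3cc(=O)c4cc(C(F)(F)F)cc([N+](=O)[O-])c4s3)CC2)CC1)c1cccc(C(F)(F)F)c1` gives > 64 ug/mL (a limit)
compound 2 `O=C(OC1CCC(CN2CCN(c3cc(=O)c4cc(C(F)(F)F)cc([N+](=O)[O-])c4s3)CC2)CC1)c1ccc(C(F)(F)F)cc1` gives > 64 ug/mL (a limit)

Compound 2 thus stands only at a limit, with no number to start from. Compound 3 `COc1ccc(C(=O)OC2CCC(CN3CCN(c4cc(=O)c5cc(C(F)(F)F)cc([N+](=O)[O-])c5s4)CC3)CC2)cc1` carries methoxy in place of trifluoromethyl on an aromatic carbon. Within the data shown here, the one measured step bearing on this is a step that the two limits leave unreadable from compound 1 to compound 2 and it offers no size to carry over. Given the limit of > 64 ug/mL in this assay, at which 2 of the 2 values shown sit, as the only evidence, no step beyond the scatter is expected in this assay and no direction can be named. The estimated step is a number no higher from compound 2 to compound 3 (the limit leaves the size open) and it should be read as no real change. Compound 3 is expected at 64 ug/mL within a range of 32 ug/mL to 128 ug/mL. A limit rather than a number may well be the outcome for this compound.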

Compound 3, half-maximal inhibitory concentration: > 64 ug/mL
Compound 3 gave a limit, no number (the forecaster's own chance of this, stated with the estimate: 85%); the middle value lies on the limit itself.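

In this assay, among these compounds, compound 3 gives only a limit, as do compound 1 and compound 2, so no step among them can be read. The compounds shown leave open whether the group on the carbonyl changes this read-out at all: the limit of > 64 ug/mL in this assay, at which 3 of the 3 values shown sit.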